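This account rests on a few compounds, and the source may have more. Where it says the series, first, only, none or still open, it means among the compounds named here.

In an ADME assay on HaCaT cells (Homo sapiens) for cytotoxicity, read by MTT assay, with a stated time of 48 h (on this read-out higher numbers stand for weaker inhibition and lower numbers for stronger inhibition), compound 1 `COc1ccc2[nH]c(-c3cn(-c4ccccc4)nc3-c3ccccc3)nc2c1` gives > 50000 nM as a limit only. Compound 2 `COc1ccc2[nH]c(-c3cn(-c4ccccc4)nc3-c3ccc(F)cc3)nc2c1` likewise gives > 50000 nM as a limit. Compound 3 `Clc1ccc(-c2nn(-c3ccccc3)cc2-c2nc3cc(Cl)ccc3[nH]2)cc1` stands at > 50000 nM which is again a limit and not a number. The whole series sits there: the limit of > 50000 nM in this assay, at which 3 of the 3 values shown sit, is all that the data show. Compound 4 `COc1ccc2[nH]c(-c3cn(-c4ccccc4)nc3-c3ccc(Cl)cc3)nc2c1` differs from compound 3 by methoxy in place of chloro on an aromatic carbon and so carries the methoxy of compound 1 and compound 2. Among the measured compounds shown here, the one measured step that the two limits leave unreadable from compound 1 to compound 2 concerns a different change and gives no size to carry over. No step beyond the scatter is expected in this assay in either direction. The estimated step is a number no higher from compound 3 to compound 4 (the limit leaves the size open) on present data. Compound 4 is estimated at 50000 nM with a range of 25000 nM to 100000 nM and a limit is the likely outcome.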

Compound 4, half-maximal inhibitory concentration: > 50000 nM
Compound 4: a limit, no number (the forecaster's own chance of this, stated with the estimate: 85%); the middle value lies on the limit itself.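

In this assay compound 4 gives > 50000 nM, a limit and not a number. No step can be read between compound 4 and compound 1, compound 2 or compound 3: the limit of > 50000 nM in this assay, at which 4 of the 4 values shown sit.

The compounds shown leave open whether any substituent change in the series alters the read-out.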